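Swapping chloro for methoxy on an anilino ring

The source may hold more compounds than are shown below. What is called first, only, known or untested is meant among the compounds shown, and "the series" means these compounds.

Compound 1 `COc1ccc(-c2nc(C(=O)/C=C\Nc3ccc4[nH]ccc4c3)c3ccccn23)cc1` gives 17400 nM in a functional assay on HCT-116 cells (Homo sapiens) for cytotoxicity, read by MTT assay, with a stated time of 48 h; a higher number here means a weaker inhibitor, a lower number a stronger inhibitor.
Compound 2 `COc1ccc(N/C=C\C(=O)c2nc(-c3ccc(F)cc3)n3ccccc23)cc1` gives > 30000 nM in this assay, which is a limit of the assay.
Compound 3 `COc1ccc(-c2nc(C(=O)/C=C\Nc3ccc(Cl)cc3)c3ccccn23)cc1` gives > 30000 nM in this assay, also a limit of the assay.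

Compound 3 thus sits at the weak end of the numbers, at the limit of > 30000 nM in this assay, at which 2 of the 3 values shown sit. Compound 4 `COc1ccc(N/C=C\C(=O)c2nc(-c3ccc(OC)cc3)n3ccccc23)cc1` differs from it by methoxy in place of chloro on an aromatic carbon. For the measured compounds named here, the only measured step that touches this amine nitrogen is an at least 1.7-fold higher number from compound 1 to compound 3 (0.23 log units; that floor lies within the scatter), so the anilino group has given no strong inhibitor here. Compound 2 already carries the methoxyphenylamino group and reaches only the limit. Compound 4 is therefore expected to stay weak, with an estimated step that the limit leaves unreadable from compound 3 to compound 4, and an estimated value of 35000 nM (range 15000 nM to 100000 nM).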

Compound 4, half-maximal inhibitory concentration: > 30000 nM
Compound 4: a limit, no number; the forecaster's own chance of this, stated with the estimate: 70%; the middle value lies beyond the limit too.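

Putting 4-methoxyphenyl in place of 1H-indol-5-yl on the amine nitrogen gives an at least 1.7-fold higher number from compound 1 to compound 4 (0.23 log units; that floor lies within the scatter). The steps to compound 4 from compound 3 and from compound 2 cannot be read, as each joins two limits. What compound 4 adds is that neither chloro nor methoxy on this anilino group brings a value off the limit in this assay: the limit of > 30000 nM in this assay, at which 3 of the 4 values shown sit.

On these data alone, whether an amine or a carboxylic acid in place of methoxy on this ring would give a readable number stays open. So does whether any other group at this place would match the 1H-indol-5-yl group of compound 1.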